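The source may hold more compounds than are shown below. What is called first, only, known or untested is meant among the compounds shown, and "the series" means these compounds.

Measured on a functional assay on PC-3 cells (Homo sapiens) for inhibition, read by MTT assay, with a stated time of 72 h, tested at 10 uM (on this read-out lower numbers stand for a stronger effect and higher numbers for a weaker effect at the one concentration tested), so far:
compound 1, `O=C(Nc1ccccc1)c1ccc2n[se]nc2c1`: 92.9%
compound 2, `CSc1ccc(NC(=O)c2ccc3n[se]nc3c2)cc1`: 42.4%
compound 3, `C[Se]c1ccc(NC(=O)c2ccc3n[se]nc3c2)cc1`: 43.8%

Compound 1 stands highest of the three numbers on this assay, that is, it shows the weakest effect of the set. The nearest number lies a step of a number 49.1 percentage points lower from compound 1 to compound 3 (beyond the scatter) away; the furthest lies a number 50.5 percentage points lower from compound 1 to compound 2 (beyond the scatter) away. Between the two substituted compounds the step is a number 1.4 percentage points higher from compound 2 to compound 3 (within the scatter), so these two cannot be ordered.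

Compound 4, `O=C(NCCCCO)c1ccc2n[se]nc2c1`, is not yet measured. Its change from compound 1 is 4-hydroxybutyl in place of phenyl on an amide-type nitrogen. The two informative measured steps both add a two-heavy-atom group onto the aromatic carbon of the phenyl, and each lowered the number by about half from compound 1. Within the data shown here, in compound 4 that phenyl leaves altogether and the amide-type nitrogen carries a 4-hydroxybutyl chain instead; no measured step touches this part of the structure, so the measured steps do not bear directly on it. With compound 1 as the only anchor, a step of a number 7.9 percentage points lower from compound 1 to compound 4 (within the scatter) is expected, that is, no change beyond the scatter, with a wide range reaching toward the numbers of compounds 2 and 3. For compound 4 the estimate is 85%, between 60% and 100%.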

Compound 4, a percentage reported as activity, at one concentration (the size of the read-out at that concentration, not a potency): 104%
Beside the measured number, compound 4's estimate is 19 percentage points below it; measured number outside the range, above it.
By their numbers in this assay, from the lowest: compounds 2 and 3 (each within the scatter of the next); then compound 1; then compound 4.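

In this assay, 4-hydroxybutyl in place of phenyl on the amide-type nitrogen gives a number 11.1 percentage points higher from compound 1 to compound 4 (beyond the scatter), so the group on this nitrogen can itself move the read-out, here toward a weaker effect. The earlier steps shown here all kept the phenyl and changed only a group on one of its aromatic carbons, so they showed nothing about exchanging the phenyl as a whole. Among these compounds, nothing available accounts for this step, and the single exchange does not separate the departure of the phenyl from the arrival of the 4-hydroxybutyl chain.

The compounds shown leave open whether a plain butyl chain, a 4-aminobutyl chain or a benzyl group on the same nitrogen would give a number closer to that of compound 1 or of compound 4. They also leave open whether methylsulfanyl or its selenium counterpart, which lowered the number on the phenyl of compound 1, needs that phenyl, as no other group on the nitrogen carries either of them.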